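Amide series on the shared core: anilide variation

This account rests on a few compounds, and the source may have more. Where it says the series, first, only, none or still open, it means among the compounds named here.

Compound 1 `COc1ccc(-c2c(I)c(=O)c3c(OC)cc(OC)cc3n2S(=O)(=O)c2ccc(OC)cc2)cc1` and compound 2 `COc1ccc(-c2cc(=O)c3c(OC)cc(OC)cc3n2S(=O)(=O)c2cccc([N+](=O)[O-])c2)cc1` carry a sulfonyl substituent on the ring nitrogen of the shared core. In an ADME assay on BJ cells (Homo sapiens) for antiproliferative activity, with a stated time of 72 h (a lower number here means that less compound is needed, a higher number that more compound is needed for the effect), compound 1 reaches only the limit > 34400 nM (the limit of > 34400 nM in this assay, at which 1 of the 3 values shown sits). Compound 2 likewise gives only the limit > 39600 nM in this assay (the limit of > 39600 nM in this assay, at which 1 of the 3 values shown sits). For the measured compounds named here, compound 3 `COc1cc(OC)c2c(=O)cc(C(=O)Nc3ccc(C4CCCCC4)cc3)[nH]c2c1` is the amide with a free ring nitrogen, and in this assay compound 3 gives 36200 nM, the only number among the three values. Compound 4 `COc1cc(OC)c2c(=O)cc(C(=O)Nc3ccc(Oc4ccc(F)cc4)cc3)[nH]c2c1` keeps the amide and differs from compound 3 by 4-fluorophenoxy in place of cyclohexyl on an aromatic carbon. Going by the values given here, no measured pair in the set mirrors this change, so the expectation rests on the number for compound 3 alone. The step from compound 3 to compound 4 is expected to be small, a 1.2-fold lower number from compound 3 to compound 4 (0.08 log units; within the scatter), within the usual scatter rather than beyond it. Compound 4 is therefore estimated at 30000 nM in this assay, with a range from 10000 nM to 90000 nM, and a real chance that only a limit is reported.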

Compound 4, half-maximal effective concentration: > 50000 nM
Compound 4: no number, only a limit; the forecaster's own chance of this, stated with the estimate: 40%; at least 1.6-fold (0.22 log units) between middle value and limit.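

In this assay compound 4 gives only a limit, > 50000 nM, not a number. Exchanging cyclohexyl for 4-fluorophenoxy on an aromatic carbon, para to a large group, gives an at least 1.3-fold higher number from compound 3 to compound 4 (0.14 log units; that floor lies within the scatter). This first readable step at this position shows no fall in the number when the saturated carbon ring gives way to an aromatic ring joined through oxygen, but a real rise is not established, as the floor of the step does not clear the scatter.

Where the true value of compound 4 lies past its limit remains open, so the full size of the step cannot be read. Also open, going by these compounds, is whether a dimethylamino group or a carboxylic acid in place of cyclohexyl would give a measurable change in this assay.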